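Thiazole acetic acids at the prostaglandin D2 receptor 2

The source may report more compounds than this note shows. Statements on the series, on what has been measured and on what is new or still open speak of the compounds shown alone.

Three compounds of one series have numbers. Compound 1 `O=C(O)Cc1sc(COc2ccc(Cl)cc2)nc1-c1ccc(Cl)cc1` gives 32 nM in an in vitro assay on HEK385-7 cells for displacement of a labelled ligand from prostaglandin D2 receptor 2 (Homo sapiens); a higher number here means a weaker inhibitor, a lower number a stronger inhibitor. Compound 3 `O=C(O)Cc1sc(C(c2ccccc2)c2ccccn2)nc1-c1ccc(Cl)cc1` gives 810 nM in this assay. Compound 2 `NS(=O)(=O)c1cccc(-c2nc(C(c3ccc(F)cc3)c3ccc(F)cc3)sc2CC(=O)O)c1` gives 140 nM in this assay and stands second highest of the three: compound 1 lies nearest, with a lower number, and compound 3 lies furthest, with a higher number, both gaps beyond the scatter.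

Compound 4 `Nc1cc(-c2nc(C(c3ccc(F)cc3)c3ccc(F)cc3)sc2CC(=O)O)cc(F)n1` has not been measured. It differs from compound 2 in one place: 2-amino-6-fluoropyridin-4-yl in place of 3-sulfamoylphenyl on an aromatic carbon. Within the data shown here, no measured pair follows this change, so the direction is open. The expected step from compound 2 to compound 4 is a 1.8-fold higher number from compound 2 to compound 4 (0.25 log units; within the scatter) in this assay, a modest rise with wide uncertainty. Compound 4 is therefore estimated at 250 nM in this assay, within a range from 70 nM to 900 nM.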

Compound 4, half-maximal inhibitory concentration: 220 nM
Compound 4: middle estimate off by 1.1-fold (0.06 log units), on the high side; the range from low to high includes it.
By their numbers in this assay, from the lowest: compound 1; then compounds 2 and 4 (each within the scatter of the next); then compound 3.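

In this assay the step is a 1.6-fold higher number from compound 2 to compound 4 (0.20 log units; within the scatter) when 2-amino-6-fluoropyridin-4-yl takes the place of 3-sulfamoylphenyl on this aromatic carbon. The position therefore carries a six-membered aromatic ring with 1 hetero atom as well as one of carbon only, and the sulfamoyl group is not needed to keep the number within the scatter. Nothing on hand explains this result.

On these data alone, what a plain phenyl, or a pyridine ring lacking either the amino group or the fluorine, would give on this carbon stays open. So does the effect of a carboxamide in place of the sulfamoyl group.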